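This account rests on a few compounds, and the source may have more. Where it says the series, first, only, none or still open, it means among the compounds named here.

Of the compounds shown here, three sharing one core have been tested in a toxicity assay on HeLa cells (Homo sapiens) for cytotoxicity, read by MTT assay, with a stated time of 24 h; a higher number here means a weaker inhibitor, a lower number a stronger inhibitor. Compound 1, `CCN1CCN(C(=S)SCC(O)Cn2c([N+](=O)[O-])cnc2C)CC1`, gives only a limit there, > 5000000 nM. That limit is the limit of > 5000000 nM in this assay, at which 1 of the 3 values shown sits. Compound 2, `Cc1ncc([N+](=O)[O-])n1CC(O)CSC(=S)N1CCOCC1`, gives 4520000 nM in this assay, and compound 3, `Cc1ncc([N+](=O)[O-])n1CC(O)CSC(=S)N1CCC(C)CC1`, gives 1820000 nM. Of the two real numbers, compound 3 stands lowest, with compound 2 nearest: a 2.5-fold lower number from compound 2 to compound 3 (0.40 log units; beyond the scatter). From the limit, an at least 2.7-fold lower number from compound 1 to compound 3 (0.43 log units; beyond the scatter), whereas an at least 1.1-fold lower number from compound 1 to compound 2 (0.04 log units; that floor lies within the scatter).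

Compound 4, `CCN(C)C(=S)SCC(O)Cn1c([N+](=O)[O-])cnc1C`, differs from compound 3 in one place: ethyl(methyl)amino in place of 4-methylpiperidin-1-yl on a thiocarbonyl carbon. Going by the values given here, no measured step exchanges a ring amine for an open chain, so the change is only partly covered by what is known. The two measured steps, a 2.5-fold lower number from compound 2 to compound 3 (0.40 log units; beyond the scatter) and an at least 2.7-fold lower number from compound 1 to compound 3 (0.43 log units; beyond the scatter), show that swapping the amine on the thiocarbonyl carbon shifts the number in this assay, and that the 4-methylpiperidin-1-yl group gave the lowest number of the set. Leaving that group is therefore expected to raise the number, by an estimated 1.9-fold higher number from compound 3 to compound 4 (0.28 log units; within the scatter). Compound 4 is expected to give about 3500000 nM in this assay, with a likely range from 1500000 nM to 8000000 nM.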

Compound 4, half-maximal inhibitory concentration: 4150000 nM
Beside the measured number, compound 4's estimate is 1.2-fold (0.07 log units) below it; low and high end bracket the measured number.
By their numbers in this assay, from the lowest: compound 3; then compounds 4 and 2 (each within the scatter of the next). At a limit, above all of these: compound 1.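

Compound 4 brings the first open-chain amine to this thiocarbonyl carbon, and in this assay the change from the 4-methylpiperidin-1-yl ring to ethyl(methyl)amino gives a 2.3-fold higher number from compound 3 to compound 4 (0.36 log units; beyond the scatter). Set against the morpholin-4-yl group, the open chain gives a 1.1-fold lower number from compound 2 to compound 4 (0.04 log units; within the scatter), so these two groups cannot be told apart here, and a ring alone does not bring the number down; compound 3 is the only compound with a real number that stands clear of the others. Compound 1 gives only a limit, so the step of an at least 1.2-fold lower number from compound 1 to compound 4 (0.08 log units; that floor lies within the scatter) rests on that limit and adds little by itself: the limit of > 5000000 nM in this assay, at which 1 of the 4 values shown sits.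

The compounds shown do not settle whether the lower number of compound 3 goes with the methyl group on its ring or with the all-carbon ring as a whole; a plain piperidin-1-yl group and a longer open chain such as dibutylamino on the thiocarbonyl carbon would help separate the two. Also open, from the compounds shown here alone, is how the number would respond to a carboxylic acid carried on the amine part.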